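A few compounds are considered here, and "the series" means these few. Any claim that something is new, unique, unknown or untested is made for them only; others in the source may bear on it.

Of the compounds shown here, three have been measured in an assay on cells for displacement of a labelled ligand from prostaglandin E2 receptor EP4 subtype (Homo sapiens), read by scintillation counting; on this read-out higher numbers stand for weaker inhibition and lower numbers for stronger inhibition. Compound 1 `COc1ccc(-c2ccc(OCc3cc(C(=O)NS(=O)(=O)c4c(C)noc4C)oc3C)cc2)c(C)c1` gives 24 nM, compound 2 `Cc1oc(C(=O)NS(=O)(=O)c2ccccc2)cc1COc1ccc(-c2ccc(OC(F)F)cc2)cc1` gives 1.3 nM, and compound 3 `COc1ccc(-c2ccc(OCc3cc(C(=O)NS(=O)(=O)c4c(C)noc4C)oc3C)cc2)nc1` gives 13 nM. Among these three numbers compound 3 stands second highest; the step of a 1.8-fold lower number from compound 1 to compound 3 (0.27 log units; within the scatter) is within the scatter, while compound 2 shows a number well below that of compound 3, although the two differ in more than one place, so no single step between them is shown.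

Compound 4 `Cc1noc(C)c1S(=O)(=O)NC(=O)c1cc(COc2ccc(-c3ccc(OC(F)F)cc3)cc2)c(C)o1` has not yet been measured. It differs from compound 3 in one place: 4-(difluoromethoxy)phenyl in place of 5-methoxypyridin-2-yl on an aromatic carbon. For the measured compounds named here, no measured pair isolates this exchange. Going by the values given here, the only single step in hand, a 1.8-fold lower number from compound 1 to compound 3 (0.27 log units; within the scatter), swaps one group for another on the same aromatic carbon and stays within the scatter, so exchanges at this position need not move the number much. Compound 2 carries the same 4-(difluoromethoxy)phenyl group that enters here and shows a number well below compound 3, but it also differs from compound 4 elsewhere, so it points only loosely. The step expected here, a 2.6-fold lower number from compound 3 to compound 4 (0.41 log units; beyond the scatter), is therefore modest. The estimate for compound 4 in this assay is 5 nM, with a range from 1.5 nM to 16 nM.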

Compound 4, inhibition constant in the prostaglandin E2 receptor EP4 subtype assay: 0.6 nM
Estimate against measurement, compound 4: 8.3-fold (0.92 log units) above; measured number outside the range, below it.
By their numbers in the prostaglandin E2 receptor EP4 subtype assay, from the lowest: compound 4; then compound 2; then compounds 3 and 1 (each within the scatter of the next).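

In the prostaglandin E2 receptor EP4 subtype assay, this position turns out to matter a great deal: a 1.8-fold lower number from compound 1 to compound 3 (0.27 log units; within the scatter) gave little sign of it, yet the 4-(difluoromethoxy)phenyl group brings a 22-fold lower number from compound 3 to compound 4 (1.34 log units; beyond the scatter) and a 40-fold lower number from compound 1 to compound 4 (1.60 log units; beyond the scatter), whereas the exchange on the sulfonyl sulfur gives only a 2.2-fold lower number from compound 2 to compound 4 (0.34 log units; beyond the scatter). The same exchange that lowers the binding number also comes with a steep loss in a physicochemical assay for solubility, in phosphate buffer, with a stated time of 24 h, at pH 7.4; on this read-out higher numbers stand for higher solubility and lower numbers for lower solubility: the measured solubility of compound 3, 90 ug/mL, and of compound 4, < 0.6 ug/mL, an at least 150-fold lower number (2.17 log units; beyond the scatter) In the physicochemical assay compound 3 gives 90 ug/mL. In the physicochemical assay compound 4 gives < 0.6 ug/mL, which is a limit of the assay and not a number: the limit of < 0.6 ug/mL in the physicochemical assay, at which 1 of the 2 values shown sits.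

This exchange replaces the ring and the group on it together, and the compounds shown do not tell which of the two goes with the change in either read-out. As far as these compounds go, a 4-methoxyphenyl or a 5-(difluoromethoxy)pyridin-2-yl group at this place would separate the two, and how an amine or a carboxylic acid on this ring would fare in both read-outs also remains open.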